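The compounds below may be only part of what the source reports. "The series", "measured", "known", "first", "only" and "open" are said of these compounds alone.

Compound 2 `CCCCN(CCCN1CCCCC1)c1cc(-c2ccccc2)no1` gives no number at all, only a limit. In a functional assay for antagonist activity at proteinase-activated receptor 1 (Homo sapiens) (on this read-out lower numbers stand for stronger inhibition and higher numbers for weaker inhibition), compound 2 gives > 40000 nM, which is a limit of the assay rather than a measured value. Compound 1 `c1ccc(CN(CCCN2CCCCC2)c2cc(-c3ccccc3)no2)cc1` carries a phenyl where compound 2 carries the propyl, and in this assay compound 1 gives 9000 nM. Compound 3 `c1ccc(-c2cc(N(CCCN3CCCCC3)CC3CCCCC3)on2)cc1` carries a cyclohexyl at that place. In this assay compound 3 gives > 10000 nM, again a limit. The change to compound 4 `c1ccc(-c2cc(N(CCCN3CCCCC3)Cc3ccc4ccccc4c3)on2)cc1` is naphthalen-2-yl in place of propyl on a saturated chain carbon bound to a nitrogen on an aromatic ring. The step that bears on it most is an at least 4.4-fold higher number from compound 1 to compound 2 (0.64 log units; beyond the scatter), which shows the phenyl giving a clearly lower number than the propyl. The steps of an at least 1.1-fold higher number from compound 1 to compound 3 (0.04 log units; that floor lies within the scatter) and a step that the two limits leave unreadable from compound 2 to compound 3 add little because the limit of > 10000 nM in this assay, at which 1 of the 3 values shown sits, and the limit of > 40000 nM in this assay, at which 1 of the 3 values shown sits, leave their sizes unreadable. As naphthalen-2-yl brings two six-membered aromatic rings of carbon only, a return toward the number of compound 1, and possibly past it, is expected. The expected step is an at least 8.0-fold lower number from compound 2 to compound 4 (0.90 log units; beyond the scatter). The estimate for compound 4 is 5000 nM, with a range from 1500 nM to 20000 nM.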

Compound 4, half-maximal inhibitory concentration: 2000 nM
Beside the measured number, compound 4's estimate is 2.5-fold (0.40 log units) above it; the measured number falls inside the stated range.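

In this assay, going from the phenyl to naphthalen-2-yl gives a 4.5-fold lower number from compound 1 to compound 4 (0.65 log units; beyond the scatter), so at this place a larger aromatic group can still lower the number, something the phenyl of compound 1 alone could not show. Naphthalen-2-yl also stands clearly apart from the propyl, with an at least 20-fold lower number from compound 2 to compound 4 (1.30 log units; beyond the scatter), and from the cyclohexyl, with an at least 5.0-fold lower number from compound 3 to compound 4 (0.69 log units; beyond the scatter). These two sizes are only floors because compound 2 and compound 3 each gave a limit, not a number: the limit of > 10000 nM in this assay, at which 1 of the 4 values shown sits, and the limit of > 40000 nM in this assay, at which 1 of the 4 values shown sits.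

Going by these compounds, what remains open is whether the gain needs both rings to be carbon only, which a quinolinyl group, with a nitrogen in its ring system, could test. A biphenyl group or naphthalen-1-yl at this place would show how far the trend extends.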